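Benzylamino nucleoside analogues: difluoromethoxy in place of methoxy

This account rests on a few compounds, and the source may have more. Where it says the series, first, only, none or still open, it means among the compounds named here.

Three measured compounds share one core. Compound 1 `OC[C@H]1O[C@@H](n2cnc3c(NCc4cccc(Br)c4)ncnc32)[C@H](O)[C@@H]1O` gives in a functional assay on G-361 cells (Homo sapiens) for antiproliferative activity, with a stated time of 72 h (on this read-out higher numbers stand for weaker inhibition and lower numbers for stronger inhibition), a value of > 166000 nM, which is a limit of the assay and not a number. Compound 2 `COc1ccccc1CNc1ncnc2c1ncn2[C@@H]1O[C@H](CO)[C@@H](O)[C@H]1O` gives in this assay a value of > 166000 nM, again a limit of the assay rather than a number. Compound 3 `OC[C@H]1O[C@@H](n2cnc3c(NCc4ccc(Cl)c(Cl)c4)ncnc32)[C@H](O)[C@@H]1O` gives in this assay a value of 145000 nM. The step that the two limits leave unreadable from compound 1 to compound 2 cannot be read, while the steps of an at least 1.1-fold lower number from compound 1 to compound 3 (0.05 log units; that floor lies within the scatter) and an at least 1.1-fold lower number from compound 2 to compound 3 (0.05 log units; that floor lies within the scatter) have floors that fall inside the scatter. Among the compounds with values here, compound 2 therefore stands at the limit of > 166000 nM in this assay, at which 2 of the 3 values shown sit, and nothing among the measured compounds separates it from the others beyond the scatter.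

Compound 4 `OC[C@H]1O[C@@H](n2cnc3c(NCc4ccccc4OC(F)F)ncnc32)[C@H](O)[C@@H]1O` differs from compound 2 by difluoromethyl in place of methyl on an oxygen on an aromatic ring. Within the data shown here, no measured step touches the substituent on this oxygen, and none of the measured steps moves beyond the scatter, so no shift beyond the scatter is expected here either. Compound 4 is estimated at 166000 nM, with a range from 80000 nM to 400000 nM. The expected step of a number no higher from compound 2 to compound 4 (the limit leaves the size open) is judged to lie inside the scatter, and a limit rather than a number is the most probable read-out.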

Compound 4, half-maximal inhibitory concentration: > 166000 nM
Compound 4: no number, only a limit; the forecaster's own chance of this, stated with the estimate: 70%; the middle value sits exactly at the limit.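

In this assay compound 4 gives a limit of the assay and not a number, so difluoromethyl in place of methyl on this oxygen on an aromatic ring does not bring the series off that limit: the limit of > 166000 nM in this assay, at which 3 of the 4 values shown sit. The steps from compound 2 to compound 4 and from compound 1 to compound 4 cannot be read, since both ends of each are limits. Within the data shown here, the only readable new step is an at least 1.1-fold higher number from compound 3 to compound 4 (0.05 log units; that floor lies within the scatter), so it separates nothing.

As far as these compounds go, whether methyl and difluoromethyl differ at all on this oxygen stays open while both compounds sit at a limit. Also open, from the compounds shown here alone, is whether an amine or a carboxylic acid carried on a longer chain at this oxygen would give a measurable number.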